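A few compounds are considered here, and "the series" means these few. Any claim that something is new, unique, unknown or untested is made for them only; others in the source may bear on it.

The measured compounds:

Compound 1, `CCc1ccc(-c2ccc(NC3=CC(=O)c4ncncc4C3=O)cc2)cc1`: 1200 nM
Compound 2, `Cc1ccc(-c2ccc(NC3=CC(=O)c4ncncc4C3=O)cc2F)cc1`: 4800 nM
Compound 3, `COc1cccc(NC2=CC(=O)c3ncncc3C2=O)c1`: 600 nM

These three share a core and differ only in the aromatic group attached through the amine. All were tested in a functional assay on PANC-1 cells (Homo sapiens) for cytotoxicity, read by MTT assay, with a stated time of 72 h; on this read-out lower numbers stand for stronger inhibition and higher numbers for weaker inhibition. Among the three, compound 1 stands second highest. Compound 3 gives a number within the usual scatter of compound 1, so the two cannot be told apart. Compound 2 gives a clearly higher number than compound 1, which means weaker inhibition there.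

Compound 4, `O=C1C(Nc2ccc(-c3ccccc3)cc2)=CC(=O)c2ncncc21`, has not yet been measured. It differs from compound 1 in one place: hydrogen in place of ethyl on an aromatic carbon. The ethyl group on the six-membered aromatic ring of carbon only is removed, and a hydrogen takes its place.

Going by the values given here, no pair of measured compounds differs in just this way, so there is no direct guide. Compound 3, which also carries no ethyl on its ring, gives 600 nM, while compound 1 gives 1200 nM, and those two lie within the scatter. The step of a 1.3-fold higher number from compound 1 to compound 4 (0.10 log units; within the scatter) is therefore expected to stay within the scatter, with no clear direction. Compound 4 is estimated at 1500 nM, with a likely range from 500 nM to 4500 nM.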

Compound 4, half-maximal inhibitory concentration: 400 nM
For compound 4 the middle estimate is 3.8-fold (0.57 log units) above the measured one, outside the stated range (below it).
By their numbers in this assay, from the lowest: compounds 4, 3 and 1 (each within the scatter of the next, the first and the last beyond it); then compound 2.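

In this assay, going by these compounds alone, hydrogen in place of ethyl gives a 3.0-fold lower number from compound 1 to compound 4 (0.48 log units; beyond the scatter), the first one-place comparison in this set. The position para to a large group therefore does not need the ethyl group for this cytotoxicity, and the change from 4-ethylphenyl to phenyl gives stronger inhibition in this pair. Nothing shown here explains why the number falls.

On these data alone, with only hydrogen and ethyl compared directly at this place, it remains open how a propyl chain, a hydroxyl group or an amine would read there. As far as these compounds go, it is also open whether the same change would give a similar step on a different aromatic group attached through the amine, or in cell lines other than this one.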